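Chloro for Fluoro at a Second Ring Position

This account rests on a few compounds, and the source may have more. Where it says the series, first, only, none or still open, it means among the compounds named here.

Compound 1 `O=C1OC[C@H](Cc2ccccc2)[C@H]1Cc1ccccc1F` and compound 2 `O=C1OC[C@H](Cc2ccccc2)[C@H]1Cc1ccccc1Cl` share one core, and compound 2 carries chloro in place of fluoro on an aromatic carbon. In a functional assay on HL-60 cells (Homo sapiens) for cytotoxicity, read by WST assay, with a stated time of 48 h (a higher number here means that more compound is needed for the effect, a lower number that less compound is needed), compound 1 gives 72000 nM, while compound 2 gives 37000 nM, a step of a 1.9-fold lower number from compound 1 to compound 2 (0.29 log units; within the scatter). Compound 3 `O=C1OC[C@H](Cc2ccccc2)[C@H]1Cc1ccc(F)cc1` differs from compound 1 by 4-fluorophenyl in place of 2-fluorophenyl on a saturated chain carbon bound to a saturated ring carbon, and in this assay compound 3 gives 57000 nM. Compound 4 `O=C1OC[C@H](Cc2ccccc2)[C@H]1Cc1ccc(Cl)cc1` is not yet measured; it carries chloro in place of fluoro on an aromatic carbon. This is the same kind of change as that between compound 1 and compound 2, but the place differs: ortho to a large group in that pair, para to a large group here. Compound 4 is expected to show a step of a 1.6-fold lower number from compound 3 to compound 4 (0.21 log units; within the scatter), resting on the step of a 1.9-fold lower number from compound 1 to compound 2 (0.29 log units; within the scatter), which lay within the scatter. Compound 4 is therefore estimated at 35000 nM, between 18000 nM and 70000 nM.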

Compound 4, half-maximal effective concentration: 36000 nM
Estimate against measurement, compound 4: 1.0-fold (0.01 log units) below, within the range that was stated.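

In this assay, chloro in place of fluoro gave steps of matching size on the two cores: the same change on two cores in this assay, a 1.9-fold lower number (0.29 log units; within the scatter) from compound 1 to compound 2 and a 1.6-fold lower number (0.20 log units; within the scatter) from compound 3 to compound 4, 1.2-fold (0.09 log units) apart, within the scatter of two such steps

Each new step, a 1.6-fold lower number from compound 3 to compound 4 (0.20 log units; within the scatter), a 1.0-fold lower number from compound 2 to compound 4 (0.01 log units; within the scatter) and a 2.0-fold lower number from compound 1 to compound 4 (0.30 log units; within the scatter), also lies within the scatter. Within the data shown here, the match therefore shows only that the change looks alike on both cores, not that chloro truly alters the number on either, or that a real effect carries from one core to the other.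

The compounds shown leave open whether an amine or a carboxylic acid in place of the halogen would move the number beyond the scatter. They also leave open whether any such step would carry across these cores.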